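The compounds below may be only part of what the source reports. "The series", "measured", "known", "first", "only" and "open" are said of these compounds alone.

Compound 3 `CCc1ccc(Nc2cccc3c2C(=O)N(C2CCC(=O)NC2=O)C3=O)cc1` gives 17% in an assay on FRT-Jurkat cells for inhibition of nuclear factor NF-kappa-B complex (Homo sapiens), read by flow cytometry, with a stated time of 24 h, tested at 10 uM; a higher number here means more inhibition at the concentration tested (going by the name of the read-out), a lower number less inhibition. On the numbers shown, compound 3 stands with both neighbours inside the scatter: compound 2 `CC(C)c1ccc(Nc2cccc3c2C(=O)N(C2CCC(=O)NC2=O)C3=O)cc1` gives 19% and compound 1 `Cc1ccc(Nc2cccc3c2C(=O)N(C2CCC(=O)NC2=O)C3=O)cc1` gives 9%, and the steps of a number 8 percentage points higher from compound 1 to compound 3 (within the scatter) and a number 2 percentage points lower from compound 2 to compound 3 (within the scatter) are both within the scatter. Compound 4 `CCCc1ccc(Nc2cccc3c2C(=O)N(C2CCC(=O)NC2=O)C3=O)cc1` differs from compound 3 by methyl in place of hydrogen on a saturated chain carbon, two bonds along the chain from an aromatic carbon. The two measured steps that lengthen or shorten the same chain each stayed within the scatter, so no step beyond the scatter is expected in this assay for compound 4 either. Compound 4 is therefore expected to give 18%, with a range from 8% to 28%. The step of a number 1 percentage points higher from compound 3 to compound 4 (within the scatter) that this estimate means is expected to lie within the scatter.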

Compound 4, a percentage reported as inhibition, at one concentration (the size of the read-out at that concentration, not a potency): 23%
Estimate against measurement, compound 4: 5 percentage points below; measured number inside the range.
By their numbers in this assay, from the lowest: compounds 1, 3, 2 and 4 (each within the scatter of the next, the first and the last beyond it).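

In this assay the propyl chain gives the only step beyond the scatter among these compounds, with a number 14 percentage points higher from compound 1 to compound 4 (beyond the scatter) as the methyl group gives way to propyl. Taken alone, the added carbon does not separate ethyl from propyl, with a number 6 percentage points higher from compound 3 to compound 4 (within the scatter) here, and straight propyl does not separate from branched isopropyl, with a number 4 percentage points higher from compound 2 to compound 4 (within the scatter) in that comparison. Nothing measured here explains these numbers. As far as these compounds go, it remains open whether a butyl or longer chain, or an amine or carboxylic acid at the chain end, would move the number further.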